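The compounds below may be only part of what the source reports. "The series", "measured", "known", "first", "only" and "open" are said of these compounds alone.

Of the compounds shown here, two sharing one core have been measured in a functional assay on MCF7 cells (Homo sapiens) for antiproliferative activity, read by MTT assay, with a stated time of 48 h; a higher number here means a weaker inhibitor, a lower number a stronger inhibitor. Compound 1 (`CCn1c(C(=O)NCCCN(C)C)ccc1C(CC)(CC)c1ccc(OCCC(O)(CC)CC)c(C)c1`) gives 3350 nM, while compound 2 (`CCC(C)C(NC(=O)c1ccc(C(CC)(CC)c2ccc(OCCC(O)(CC)CC)c(C)c2)n1CC)C(=O)O`) gives 11300 nM, the higher of the two numbers. Among the measured compounds shown here, the only measured step is a 3.4-fold higher number from compound 1 to compound 2 (0.53 log units; beyond the scatter), with 1-carboxy-2-methylbutyl in place of 3-(dimethylamino)propyl on an amide-type nitrogen. Compound 3 (`CCn1c(C(=O)NC(C)C(=O)O)ccc1C(CC)(CC)c1ccc(OCCC(O)(CC)CC)c(C)c1`) keeps the carboxy group of compound 2 and changes only its side chain: methyl in place of sec-butyl on a saturated chain carbon bound to an amide-type nitrogen and a carbonyl carbon. For the measured compounds named here, no measured step covers this exchange, so the step to compound 2 offers only a loose sense of scale. No change beyond the scatter is therefore expected in this assay, and the expected step is a 1.2-fold higher number from compound 2 to compound 3 (0.06 log units; within the scatter). The estimated value for compound 3 is 13000 nM, with an expected range of 6000 nM to 30000 nM.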

Compound 3, half-maximal inhibitory concentration: 19700 nM
The estimate for compound 3 lay 1.5-fold (0.18 log units) below the measured number; the range from low to high includes it.
By their numbers in this assay, from the lowest: compound 1; then compounds 2 and 3 (each within the scatter of the next).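

In this assay, methyl in place of sec-butyl, on a saturated chain carbon bound to an amide-type nitrogen and a carbonyl carbon, gives a 1.7-fold higher number from compound 2 to compound 3 (0.24 log units; within the scatter) and so does not move the number beyond the scatter. The 3-(dimethylamino)propyl side chain stays apart from the carboxy-bearing side chains, since 1-carboxyethyl in its place gives a 5.9-fold higher number from compound 1 to compound 3 (0.77 log units; beyond the scatter) and the gap therefore does not depend on the sec-butyl group. No evidence is available to explain these numbers.

On these data alone, it remains open whether a phenyl ring or a longer chain on that saturated chain carbon would stay within the scatter as well. As far as these compounds go, it is also open whether a methyl ester or a primary amide in place of the carboxylic acid would bring the number closer to that of the 3-(dimethylamino)propyl compound.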